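This account rests on a few compounds, and the source may have more. Where it says the series, first, only, none or still open, it means among the compounds named here.

Measured compounds:
Compound 1, `CC(C)=CCc1cc(C(=O)Nc2cc3ccc(OCCCN4CCCCC4)c(C)c3oc2=O)ccc1O`: in a functional assay on SK-BR-3 cells (Homo sapiens) for antiproliferative activity (on this read-out higher numbers stand for weaker inhibition and lower numbers for stronger inhibition), compound 1 gives > 50000 nM, which is a limit of the assay and not a number.
Compound 2, `CCN(CC)CCCOc1ccc2cc(NC(=O)c3ccc(O)c(CC=C(C)C)c3)c(=O)oc2c1C`: in this assay compound 2 gives 4900 nM.
Compound 3, `CCCN(CCC)CCCOc1ccc2cc(NC(=O)c3ccc(O)c(CC=C(C)C)c3)c(=O)oc2c1C`: in this assay compound 3 gives > 50000 nM, again a limit of the assay and not a number.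

Compound 3 thus stands at the limit of > 50000 nM in this assay, at which 2 of the 3 values shown sit; of the three values shown, only compound 2 carries a number. The unmeasured compound 4, `CC(C)=CCc1cc(C(=O)Nc2cc3ccc(OCCCNC(C)(C)c4ccccc4)c(C)c3oc2=O)ccc1O`, differs from compound 3 in one place: (1-methyl-1-phenylethyl)amino in place of dipropylamino on a saturated chain carbon, three bonds along the chain from an oxygen on an aromatic ring. Two measured steps at this position bear on the change. There was an at least 10-fold lower number from compound 1 to compound 2 (1.00 log units; beyond the scatter), and there was an at least 10-fold higher number from compound 2 to compound 3 (1.00 log units; beyond the scatter), while a step that the two limits leave unreadable from compound 1 to compound 3. Among the measured compounds shown here, the diethylamino of compound 2 is the only group at this position that returned a readable number; the piperidin-1-yl of compound 1 and the dipropylamino of compound 3 both sit at the limit. The group entering in compound 4 has more heavy atoms than any of these. The step of an at least 1.6-fold lower number from compound 3 to compound 4 (0.22 log units; that floor lies within the scatter) is therefore expected to be small, keeping compound 4 near the limit. Compound 4 is expected to give about 30000 nM in this assay, somewhere between 5000 nM and 50000 nM, with a fair chance that only a limit is reported.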

Compound 4, half-maximal inhibitory concentration: 960 nM
For compound 4 the middle estimate is 31-fold (1.49 log units) above the measured one; measured number below the stated range.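

In this assay, a group larger than diethylamino on this saturated chain carbon no longer has to mean a loss of activity: with (1-methyl-1-phenylethyl)amino there is a 5.1-fold lower number from compound 2 to compound 4 (0.71 log units; beyond the scatter), so compound 4 now gives the lowest number of the four. The earlier compounds shown here pointed the other way, since the dipropylamino of compound 3 and the piperidin-1-yl of compound 1 both fell to the limit, and the new group has more heavy atoms than the dipropylamino it replaces. The other two steps, an at least 52-fold lower number from compound 3 to compound 4 (1.71 log units; beyond the scatter) and an at least 52-fold lower number from compound 1 to compound 4 (1.71 log units; beyond the scatter), each start from a limit of the assay and so give only a floor for their size, and compound 4 stands clear of that limit: the limit of > 50000 nM in this assay, at which 2 of the 4 values shown sit.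

The compounds shown leave open which part of the entering group goes with the lower number, the aromatic ring, the amine hydrogen or the two methyl groups on the branched carbon; a benzylamino group or a tert-butylamino group at this place would begin to separate them. They also leave open whether the same change holds on a longer chain.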